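Heteroaryl swaps on the shared core: the imidazole isomer step

This account rests on a few compounds, and the source may have more. Where it says the series, first, only, none or still open, it means among the compounds named here.

Measured in a functional assay on A-375 cells (Homo sapiens) for activation, with a stated time of 3 days; a lower number here means that less compound is needed, a higher number that more compound is needed for the effect:
- compound 1 `O=C(Nc1ccc(-c2cccnc2)cc1)C1CCCN(Cc2ccc(F)c(F)c2)C1`: 1060 nM
- compound 2 `O=C(Nc1ccc(-c2ccccn2)cc1)C1CCCN(Cc2ccc(F)c(F)c2)C1`: 11000 nM
- compound 3 `O=C(Nc1ccc(-c2c[nH]cn2)cc1)C1CCCN(Cc2ccc(F)c(F)c2)C1`: 16000 nM

Not yet measured: compound 4 `O=C(Nc1ccc(-c2ncc[nH]2)cc1)C1CCCN(Cc2ccc(F)c(F)c2)C1`.

Compound 3 carries the highest number of the three, but its gap to compound 2 lies within the scatter (a 1.5-fold higher number from compound 2 to compound 3 (0.16 log units; within the scatter)). Only compound 1 stands clearly apart (a 15-fold higher number from compound 1 to compound 3 (1.18 log units; beyond the scatter)).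

The next step is 1H-imidazol-2-yl in place of 1H-imidazol-4-yl on an aromatic carbon. The attachment point on the imidazole moves while the atoms stay the same. Going by the values given here, the nearest precedent is the pyridine pair, where a similar swap gave a large change (a 10-fold higher number from compound 1 to compound 2 (1.02 log units; beyond the scatter)). A change of this kind can therefore matter in this assay. Against that, the only measured step between compounds other than compound 1 stays within the scatter (a 1.5-fold higher number from compound 2 to compound 3 (0.16 log units; within the scatter)), and nothing measured links compound 4 to compound 1. No shift beyond the scatter is expected, in either direction, though the uncertainty is wide. The expected step is a 1.3-fold lower number from compound 3 to compound 4 (0.12 log units; within the scatter) and it stays within the scatter. Compound 4 is estimated at 12000 nM with an expected range from 4000 nM to 30000 nM in this read-out.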

Compound 4, half-maximal effective concentration: 8000 nM
The estimate for compound 4 lay 1.5-fold (0.18 log units) above the measured number; the range from low to high includes it.
By their numbers in this assay, from the lowest: compound 1; then compounds 4, 2 and 3 (each within the scatter of the next).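

In this assay, going by these compounds alone, moving the attachment point on the imidazole gives a step that stays within the scatter (a 2.0-fold lower number from compound 3 to compound 4 (0.30 log units; within the scatter)), so the large change seen between the two pyridine isomers (a 10-fold higher number from compound 1 to compound 2 (1.02 log units; beyond the scatter)) has no counterpart in this imidazole pair. Compound 4 also lies within the scatter of the pyridin-2-yl compound (a 1.4-fold lower number from compound 2 to compound 4 (0.14 log units; within the scatter)) but remains apart from the pyridin-3-yl compound (a 7.5-fold higher number from compound 1 to compound 4 (0.88 log units; beyond the scatter)); among the four groups at this place, on an aromatic carbon para to a large group, pyridin-3-yl alone stands apart, with compounds 2, 3 and 4 within the scatter of one another. The data at hand offer no measurement that would explain why this position tolerates the imidazole isomer change yet separates the pyridine isomers.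

The compounds shown leave open whether the separation of compound 1 is specific to pyridin-3-yl, since neither pyridin-4-yl nor a plain phenyl ring appears at this place. They also leave open whether the imidazole hydrogen on nitrogen has any bearing on the read-out, which a methyl group on that imidazole nitrogen could test.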